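The source may hold more compounds than are shown below. What is called first, only, known or untested is meant among the compounds shown, and "the series" means these compounds.

Values measured so far in a functional assay on ECa-109 cells (Homo sapiens) for antiproliferative activity, read by MTT assay, with a stated time of 48 h (a higher number here means a weaker inhibitor, a lower number a stronger inhibitor), each of them a limit of the assay and not a number:

- Compound 1 `Cn1cc(C2=C(c3nn(CCCN4CCCCC4)c4ncccc34)C(=O)N(c3ccc(Cl)cc3)C2=O)c2ccccc21`: > 100000 nM
- Compound 2 `Cn1cc(C2=C(c3nn(CCCn4ccnc4)c4ncccc34)C(=O)NC2=O)c2ccccc21`: > 100000 nM
- Compound 3 `Cn1cc(C2=C(c3nn(CCCn4cccc4)c4ncccc34)C(=O)N(c3ccccc3)C2=O)c2ccccc21`: > 100000 nM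

Compound 2 has only a limit, > 100000 nM. The whole set stands at the limit of > 100000 nM in this assay, at which 3 of the 3 values shown sit.

Compound 4 `Cn1cc(C2=C(c3nn(CCCO)c4ncccc34)C(=O)NC2=O)c2ccccc21` differs from compound 2 by carrying hydroxy in place of 1H-imidazol-1-yl on a saturated chain carbon, three bonds along the chain from an aromatic nitrogen. Within the data shown here, no two measured compounds differ in one place only, so no measured step serves as a guide. A modest move toward a stronger inhibitor in this assay is expected, and the estimated step is an at least 2.0-fold lower number from compound 2 to compound 4 (0.30 log units; that floor lies within the scatter). A further reading at the limit would fit this expectation too. For compound 4 the estimated value is 50000 nM, with an expected range from 10000 nM to 100000 nM.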

Compound 4, half-maximal inhibitory concentration: > 100000 nM
Compound 4: only a limit was reported; the forecaster's own chance of this, stated with the estimate: 60%; middle value at least 2.0-fold (0.30 log units) away from the limit.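

In this assay compound 4 gives > 100000 nM, a limit of the assay and not a number. Among these compounds, compound 2 also sits at a limit, and no step from compound 2 to compound 4 can be read. The compounds shown leave open which change, if any, would give a measurable value: the limit of > 100000 nM in this assay, at which 4 of the 4 values shown sit.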